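Swapping pyridin-3-yl for 3-cyano-5-fluorophenyl at a carbonyl carbon

This account rests on a few compounds, and the source may have more. Where it says the series, first, only, none or still open, it means among the compounds named here.

Measured compounds:
compound 1, `CCOC(=O)[C@H]1CC[C@@H](n2/c(=N/C(=O)c3ccccc3)[nH]c3ccc(CN4CCCCC4)cc32)CC1`: 706 mL.min-1.g-1
compound 2, `CC(C)NC(=O)[C@H]1CC[C@@H](n2/c(=N/C(=O)c3cccnc3)[nH]c3ccc(CN4CCC(C(C)(C)O)CC4)cc32)CC1`: < 14 mL.min-1.g-1

In an in vitro ADME assay on microsomes from liver (Rattus norvegicus) for metabolic stability (on this read-out lower numbers stand for slow clearance and higher numbers for fast clearance), compound 1 gives 706 mL.min-1.g-1. For compound 2 this assay reports only a limit, < 14 mL.min-1.g-1, so compound 2 stands at the limit of < 14 mL.min-1.g-1 in this assay, at which 1 of the 2 values shown sits, with no number of its own. Compound 3, `CC(C)NC(=O)[C@H]1CC[C@@H](n2/c(=N/C(=O)c3cc(F)cc(C#N)c3)[nH]c3ccc(CN4CCC(C(C)(C)O)CC4)cc32)CC1`, differs from compound 2 in one place: 3-cyano-5-fluorophenyl in place of pyridin-3-yl on a carbonyl carbon. Within the data shown here, no measured step covers this change, so the expectation rests on compound 2 alone. Compound 3 is estimated at 20 mL.min-1.g-1, in a range from 10 mL.min-1.g-1 to 60 mL.min-1.g-1. The expected step is an at least 1.4-fold higher number from compound 2 to compound 3 (0.15 log units; that floor lies within the scatter), small and toward slightly faster clearance, if any.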

Compound 3, intrinsic clearance in microsomes: 30 mL.min-1.g-1
Compound 3: the middle estimate sits 1.5-fold (0.18 log units) below what was measured; measured number inside the range.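

At this place on the carbonyl carbon, 3-cyano-5-fluorophenyl in place of pyridin-3-yl gives, in this assay, an at least 2.1-fold higher number from compound 2 to compound 3 (0.33 log units; beyond the scatter). With the rest of the molecule unchanged, the ring on this carbonyl alone therefore moves the read-out toward faster clearance. The full size of the step stays unknown, because compound 2 has only a limit: the limit of < 14 mL.min-1.g-1 in this assay, at which 1 of the 3 values shown sits.

Which part of the new ring carries the step remains open, whether the nitrile, the fluorine or the loss of the ring nitrogen. A 3-cyanophenyl and a 3-fluorophenyl on this carbonyl would separate these.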